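Replacing a 4-Fluorophenyl Arm with a 2-Chlorophenyl Arm

The source may hold more compounds than are shown below. What is called first, only, known or untested is meant among the compounds shown, and "the series" means these compounds.

Measured so far:
Compound 1, `CC1=CC[C@H](C(C)(C)NC(=S)N/N=C/c2ccc(O)cc2)CC1`, in a functional assay on NCI-H460 cells (Homo sapiens) for inhibition, read by sulforhodamine B assay, with a stated time of 48 h; a lower number here means a stronger inhibitor of growth, a higher number a weaker inhibitor of growth: > 100000 nM, a limit of the assay.
Compound 2, `CC1=CC[C@H](C(C)(C)NC(=S)N/N=C/c2ccc(F)cc2)CC1`, in this assay: > 100000 nM, a limit of the assay.

Compound 2 therefore stands at the ceiling of this assay rather than at a number. Among the compounds with values here, the one change between them, a step that the two limits leave unreadable from compound 1 to compound 2, cannot be read because of the limit of > 100000 nM in this assay, at which 2 of the 2 values shown sit. Compound 3, `CC1=CC[C@H](C(C)(C)NC(=S)N/N=C/c2ccccc2Cl)CC1`, differs from compound 2 by 2-chlorophenyl in place of 4-fluorophenyl on a carbon with a double bond to nitrogen. Within the data shown here, no measured step bears on this change, since the only step known is the unreadable one. Compound 3 is therefore expected to sit at the same limit, with a number no higher from compound 2 to compound 3 (the limit leaves the size open) as the expected step. The estimated value of compound 3 is 100000 nM, with an expected range from 30000 nM to 300000 nM.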

Compound 3, concentration for 50% growth inhibition: 64500 nM
The estimate for compound 3 lay 1.6-fold (0.19 log units) above the measured number; measured number inside the range.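

In this assay, compound 3 is the first of the compounds shown to give a number rather than a limit, so at this carbon with a double bond to nitrogen the 2-chlorophenyl arm yields a readable value, which neither the 4-fluorophenyl nor the 4-hydroxyphenyl arm does. The change reads as an at least 1.5-fold lower number from compound 2 to compound 3 (0.19 log units; that floor lies within the scatter), and against the 4-hydroxyphenyl arm as an at least 1.5-fold lower number from compound 1 to compound 3 (0.19 log units; that floor lies within the scatter). Both steps are floors only, and their true size stays open because the other two values are limits: the limit of > 100000 nM in this assay, at which 2 of the 3 values shown sit.

On these data alone, whether the value of compound 3 follows from the chlorine itself or from where it sits on the ring stays open. As far as these compounds go, how a 4-chlorophenyl arm or a 2-fluorophenyl arm would read in this assay is also open.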